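The compounds below may be only part of what the source reports. "The series", "measured", "known", "first", "only" and "open" are said of these compounds alone.

Measured so far:
Compound 1, `CC(C)C/N=C(\NC#N)Nc1cccnc1`: 20 mg/kg
Compound 2, `CC(C)C(/N=C(\NC#N)Nc1cccnc1)C(C)C`: 5 mg/kg
Compound 3, `CC(C)(C)C(C)(C)/N=C(\NC#N)Nc1cccnc1`: 50 mg/kg

In a functional assay on the whole organism (blood, strain Wistar-Okamoto) with Rattus norvegicus as the target, with a stated time of 5 days (a lower number here means that less compound is needed, a higher number that more compound is needed for the effect), compound 1 gives 20 mg/kg, the second highest of the three numbers. Its nearest neighbour is compound 3, which gives 50 mg/kg, while compound 2 gives 5 mg/kg and stands furthest away. Within the data shown here, the one step that can be read directly, a 4.0-fold lower number from compound 1 to compound 2 (0.60 log units; beyond the scatter), comes from putting isopropyl in place of hydrogen on a saturated chain carbon bound to a double-bonded nitrogen and a saturated chain carbon.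

Compound 4, `C=C(C)C/N=C(\NC#N)Nc1cccnc1`, is not yet measured. It differs from compound 1 as follows: 1-methylethenyl in place of isopropyl on a saturated chain carbon bound to a double-bonded nitrogen. Among the measured compounds shown here, no measured step touches this kind of change; the only step in hand adds a group to the same saturated chain carbon rather than replacing isopropyl by 1-methylethenyl, so it bears on the question only loosely. Without a step that speaks to this replacement, the group count being unchanged, the step of no change at the digits printed from compound 1 to compound 4 (within the scatter) is expected to stay within the scatter. For compound 4 in this assay an estimate of 20 mg/kg is therefore expected, with a range from 8 mg/kg to 50 mg/kg.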

Compound 4, minimum effective dose: 20 mg/kg
Compound 4: the middle estimate sits on the measured number at the digits printed, and the stated range covers the measured number.
By their numbers in this assay, from the lowest: compound 2; then compounds 1 and 4 (each within the scatter of the next); then compound 3.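

In this assay, putting 1-methylethenyl in place of isopropyl on a saturated chain carbon bound to a double-bonded nitrogen gives no change at the digits printed from compound 1 to compound 4 (within the scatter). Among these compounds, the earlier compounds offered only one readable step at this carbon, a 4.0-fold lower number from compound 1 to compound 2 (0.60 log units; beyond the scatter), which adds an isopropyl group to the chain; the new step instead keeps the same count of heavy atoms and brings in a double bond outside aromatic rings, and the minimum effective dose stays within the scatter, so in this pair isobutyl and 2-methylprop-2-en-1-yl cannot be told apart by this read-out. No measurement is at hand that would explain why the two groups read alike, so the result stands as an observation about this one pair.

The compounds shown leave open whether this tolerance extends beyond the single pair, for instance to a cyclopropyl ring, a longer chain or a terminal hydroxyl group in the same place. They also leave open whether 1-methylethenyl would read the same way on the more branched chain of compound 2.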